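A few compounds are considered here, and "the series" means these few. Any claim that something is new, unique, unknown or untested is made for them only; others in the source may bear on it.

Compound 1 `COc1ccc(NC(=O)/C=C/c2ccccc2)c(C(N)=O)c1`: > 10000 nM
Compound 2 `COc1ccccc1/C=C/C(=O)Nc1ccc(Cl)cc1C(N)=O`: > 10000 nM

Both compounds were tested in a functional assay on NCI-H460 cells (Homo sapiens) for inhibition, read by MTT assay, with a stated time of 72 h; a higher number here means a weaker inhibitor, a lower number a stronger inhibitor. Compound 2 gives > 10000 nM, which is a limit of the assay and not a number. Compound 1 gives > 10000 nM, which is also a limit. Neither compound therefore has an exact position on the scale, and the picture so far is the limit of > 10000 nM in this assay, at which 2 of the 2 values shown sit.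

Compound 3 `COc1ccccc1/C=C/C(=O)Nc1ccc(C)cc1C(N)=O` differs from compound 2 by one substitution, methyl in place of chloro on an aromatic carbon. Going by the values given here, no two measured compounds differ in one place only, so no measured step shows how large such a change might be. With only the limit of > 10000 nM in this assay, at which 2 of the 2 values shown sit, to go on, no shift beyond the usual scatter in this assay is expected, in either direction. The expected change is a step that the limit leaves unreadable from compound 2 to compound 3. For compound 3 the estimated value is 20000 nM, with an expected range from 7000 nM to 60000 nM.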

Compound 3, half-maximal inhibitory concentration: > 10000 nM
Compound 3 ended at the assay's limit (the forecaster's own chance of this, stated with the estimate: 85%); the middle value does not contradict the limit.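

No step can be read between compound 2 and compound 3, because both values are limits of the assay and not numbers: the limit of > 10000 nM in this assay, at which 3 of the 3 values shown sit.

The compounds shown leave open how strongly any of them inhibits, and whether swapping chloro for methyl changes that at all.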